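Replacing the 2-cyanophenyl group of compound 3

The source may report more compounds than this note shows. Statements on the series, on what has been measured and on what is new or still open speak of the compounds shown alone.

Within the data shown here, in an ADME assay on microsomes from liver (Homo sapiens) for metabolic stability, with a stated time of 30 min, tested at 1 uM (a lower number here means that less of the compound is left, a higher number that more of the compound is left), compound 3 `CN(Cc1ccc(C2=NCCN2)cc1)C(=O)COCCN(C)S(=O)(=O)c1ccccc1C#N` gives 87%, the highest number of the three compounds measured so far. Compound 2 `COc1cc(C)c(S(=O)(=O)N(C)CCOCC(=O)N2CCC(C(C)(C)CN(C)C)CC2)c(C)c1` gives 36%, and compound 1 `Cc1c(Cl)ccc(S(=O)(=O)N(C)CCOCC(=O)N(C)Cc2ccc(C3=NCCN3)cc2)c1Cl` gives 8%. The next compound, compound 4 `COc1cc(C)c(S(=O)(=O)N(C)CCOCC(=O)N(C)Cc2ccc(C3=NCCN3)cc2)c(C)c1`, keeps the rest of compound 3 but carries 4-methoxy-2,6-dimethylphenyl in place of 2-cyanophenyl on a sulfonyl sulfur. Among the measured compounds shown here, only one measured step involves this place, and it is large and beyond the scatter: a number 79 percentage points higher from compound 1 to compound 3 (beyond the scatter), with 2-cyanophenyl entering in place of 2,4-dichloro-3-methylphenyl. Here 2-cyanophenyl leaves instead, though a different group enters, so that step offers only a rough guide. Compound 2 already carries 4-methoxy-2,6-dimethylphenyl on a different remainder, and it gives 36%. A large fall in this assay is therefore expected, an estimated a number 47 percentage points lower from compound 3 to compound 4 (beyond the scatter). For compound 4 the estimated value is 40%, with an expected range from 15% to 70%.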

Compound 4, percent of the compound remaining: 57%
The estimate for compound 4 lay 17 percentage points below the measured number; the measured number falls inside the stated range.
By their numbers in this assay, from the lowest: compound 1; then compound 2; then compound 4; then compound 3.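

With the rest of the molecule held the same, three groups on the sulfonyl sulfur can now be compared in this assay, rather than two. Putting 4-methoxy-2,6-dimethylphenyl in place of 2-cyanophenyl gives a number 30 percentage points lower from compound 3 to compound 4 (beyond the scatter), while putting it in place of 2,4-dichloro-3-methylphenyl gives a number 49 percentage points higher from compound 1 to compound 4 (beyond the scatter), so this group falls between the other two and close to neither. Changing this one group can therefore give three clearly separated results, not merely a high one and a low one.

Going by these compounds, the methoxy and the two methyl groups arrive together, so their separate shares remain open, as does where a plain phenyl or a 4-methoxyphenyl ring carrying no methyl groups would fall. Nothing available here explains these differences.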